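The compounds below may be only part of what the source reports. "The series", "measured", "known", "first", "only" and "open" are said of these compounds alone.

Measured so far in a functional assay on MDA-MB-435 cells (Homo sapiens) for inhibition, read by sulforhodamine B assay, with a stated time of 48 h; on this read-out higher numbers stand for weaker inhibition of growth and lower numbers for stronger inhibition of growth:
- compound 1, `Nc1cc(N)c2nc(-c3ccccc3)c(NCc3ccc(Cl)c(Cl)c3)nc2c1`: 7590 nM
- compound 2, `COc1ccc(CNc2nc3cc(N)cc(N)c3nc2-c2ccccc2)cc1OC`: 4070 nM
- compound 3, `CCOC(=O)[C@H](CCC(=O)O)NC(=O)c1ccc(Sc2nc3cc(N)cc(N)c3nc2-c2ccccc2)cc1`: 33900 nM

Compound 2 carries the lowest of the three numbers, but its standing is modest: the step of a 1.9-fold lower number from compound 1 to compound 2 (0.27 log units; within the scatter) lies within the scatter, so compound 1 and compound 2 cannot be told apart on this read-out. Within the data shown here, compound 3 is the clear outlier; in this assay compound 3 gives 33900 nM, while compound 2 gives 4070 nM, a gap beyond the scatter, though no single-site step joins the two.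

Compound 4, `COc1cc(CNc2nc3cc(N)cc(N)c3nc2-c2ccccc2)cc(OC)c1OC`, differs from compound 2 by methoxy in place of hydrogen on an aromatic carbon. Among the measured compounds shown here, the only measured step that bears on a change at the benzylic aryl ring is a 1.9-fold lower number from compound 1 to compound 2 (0.27 log units; within the scatter), which swapped the whole substitution pattern and moved the number by less than the scatter. Nothing measured here addresses a third methoxy group as such. On that basis the step from compound 2 to compound 4 is expected to be a 1.0-fold lower number from compound 2 to compound 4 (0.01 log units; within the scatter), that is, no change beyond the scatter in this assay.

Estimate for compound 4 in this assay: 4000 nM, with a range from 1500 nM to 11000 nM.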

Compound 4, concentration for total growth inhibition: 912 nM
The estimate for compound 4 lay 4.4-fold (0.64 log units) above the measured number, and the stated range ends above it.
By their numbers in this assay, from the lowest: compound 4; then compounds 2 and 1 (each within the scatter of the next); then compound 3.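

In this assay, methoxy in place of hydrogen on this aromatic carbon, where it stands ortho to a methoxy group and meta to a second one, gives a 4.5-fold lower number from compound 2 to compound 4 (0.65 log units; beyond the scatter). Among these compounds, this is a modest step, but it is the first change on this ring to move the number beyond the scatter: the earlier step, a 1.9-fold lower number from compound 1 to compound 2 (0.27 log units; within the scatter), exchanged the dichloro pattern for the dimethoxy pattern and stayed within it, so that step gave no sign that the ring could affect growth inhibition on this read-out. Nothing available accounts for the size of the new step, and it remains an observation from a single pair of compounds.

Going by these compounds, whether the step belongs to methoxy itself or would also follow from a hydroxyl, an ethoxy group or an amine on the same carbon remains open. Also open, on these data alone, is whether methoxy on this carbon would give a step of similar size with chlorine rather than methoxy groups on the rest of the ring.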